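Replacing an aryl group with a benzodioxinyl group

The source may report more compounds than this note shows. Statements on the series, on what has been measured and on what is new or still open speak of the compounds shown alone.

Measured so far:
- Compound 1, `CC(C)(C)c1ccc(CNCCCNS(=O)(=O)c2cc(C(F)(F)F)cc(C(F)(F)F)c2)cc1`, in a functional assay on BXPC-3 cells (Homo sapiens) for inhibition, read by MTT assay, with a stated time of 72 h (a higher number here means a weaker inhibitor of growth, a lower number a stronger inhibitor of growth), gives 1400 nM.
- Compound 2, `O=S(=O)(NCCCNCc1ccc(Cl)c(C(F)(F)F)c1)c1cc(C(F)(F)F)cc(C(F)(F)F)c1`, in this assay gives 7800 nM.

Compound 2 has the highest number of the two measured, so it is the weaker growth inhibitor of the pair: the step of a 5.6-fold higher number from compound 1 to compound 2 (0.75 log units; beyond the scatter) lies beyond the scatter.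

Compound 3, `O=S(=O)(NCCCNCC1COc2ccccc2O1)c1cc(C(F)(F)F)cc(C(F)(F)F)c1`, is not yet measured. Its change from compound 2 is 2,3-dihydro-1,4-benzodioxin-2-yl in place of 4-chloro-3-(trifluoromethyl)phenyl on a saturated chain carbon bound to an amine nitrogen. Among the compounds with values here, the only measured step at this same place is a 5.6-fold higher number from compound 1 to compound 2 (0.75 log units; beyond the scatter), and that step swapped one aromatic group for another, whereas here an aromatic group gives way to a group holding an additional non-aromatic ring with two oxygens. Within the data shown here, no measured step shows such a swap, so the direction cannot be read from the data; only the size of the earlier step suggests a change of comparable magnitude in this assay is plausible in either direction. Compound 3 is therefore expected near 5000 nM, within 1500 nM to 20000 nM, a step of a 1.6-fold lower number from compound 2 to compound 3 (0.19 log units; within the scatter).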

Compound 3, concentration for 50% growth inhibition: 1200 nM
Estimate against measurement, compound 3: 4.2-fold (0.62 log units) above; measured number outside the range, below it.
By their numbers in this assay, from the lowest: compounds 3 and 1 (each within the scatter of the next); then compound 2.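

In this assay, the group on the saturated chain carbon bound to an amine nitrogen need not be a single substituted phenyl ring: 2,3-dihydro-1,4-benzodioxin-2-yl in place of 4-chloro-3-(trifluoromethyl)phenyl gives a 6.5-fold lower number from compound 2 to compound 3 (0.81 log units; beyond the scatter). Set against 4-(tert-butyl)phenyl, the same group gives a 1.2-fold lower number from compound 1 to compound 3 (0.07 log units; within the scatter), so the two-ring group with its two oxygens cannot be told apart from the best phenyl group shown here. Nothing available explains why these groups rank as they do.

Going by these compounds, whether the ring oxygens matter remains open, and a 1,2,3,4-tetrahydronaphthalen-2-yl group, with carbon in their place, would test this. On these data alone, how a cyclohexyl group, which has no aromatic ring, would fare at this position also remains unknown.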